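From cyclohexyl to furan-2-yl on a shared core

The source may hold more compounds than are shown below. What is called first, only, known or untested is meant among the compounds shown, and "the series" means these compounds.

- Compound 1 `O=c1cc(NC2CCCCC2)cc(/C=C/c2ccccc2)o1`: 1.25 uM
- Compound 2 `COc1ccc(Nc2cc(C3CCCCC3)oc(=O)c2)cc1`: 4.62 uM

In a functional assay on A549 cells (Homo sapiens) for cytotoxicity, read by MTT assay, with a stated time of 72 h (a higher number here means that more compound is needed for the effect, a lower number that less compound is needed), compound 2 (4.62 uM) holds the higher number of the two, and the gap down to compound 1 (1.25 uM) lies beyond the scatter. Compound 3 `COc1ccc(Nc2cc(-c3ccco3)oc(=O)c2)cc1` has not yet been measured. It carries furan-2-yl in place of cyclohexyl on an aromatic carbon, next to the ring oxygen (furan-2-yl in place of cyclohexyl on an aromatic carbon). Going by the values given here, no two measured compounds differ in one place only, so nothing measured so far isolates this exchange. Compound 1 and compound 2 differ in more than one place, and their values offer only a rough span. In this assay a modest move toward a lower number is expected, probably not beyond the scatter (a 1.5-fold lower number from compound 2 to compound 3 (0.19 log units; within the scatter)). For compound 3 the estimated value is 3 uM (expected range 1 uM to 9 uM).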

Compound 3, concentration for half-maximal effect: 1.91 uM
The estimate for compound 3 lay 1.6-fold (0.20 log units) above the measured number; the measured number falls inside the stated range.
By their numbers in this assay, from the lowest: compounds 1 and 3 (each within the scatter of the next); then compound 2.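

In this assay, furan-2-yl in place of cyclohexyl on an aromatic carbon, next to the ring oxygen, gives a 2.4-fold lower number from compound 2 to compound 3 (0.38 log units; beyond the scatter). Going by these compounds alone, this is the first change that can be read on its own, and it shows that the group at this position affects the number: the five-membered aromatic ring with one hetero atom gives a modest gain over the six-membered non-aromatic ring of carbon only, beyond the scatter. No available evidence explains this step.

The single exchange changes ring size, aromaticity and the hetero atom together, so the compounds shown do not separate these features. As far as these compounds go, whether thiophen-2-yl or a small alkyl group such as methyl at the same place would keep the lower number remains open, as does whether the step carries over to other amino groups on the shared core.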